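The source may hold more compounds than are shown below. What is called first, only, known or untested is meant among the compounds shown, and "the series" means these compounds.

Measured compounds:
- compound 1 `CC1CC/C(=N\Nc2ccccc2I)c2ncc(C(=O)O)c(=O)n21`: in a functional assay on the whole organism for inhibition, with Rattus norvegicus as the target (a higher number here means that more compound is needed for the effect, a lower number that less compound is needed), compound 1 gives > 1000 umol/kg, which is a limit of the assay.
- compound 2 `CC1CC/C(=N\Nc2ccc(O)cc2)c2ncc(C(=O)O)c(=O)n21`: in this assay compound 2 gives > 100 umol/kg, also a limit.

Compound 2 thus stands at a limit, as the limit of > 100 umol/kg in this assay, at which 1 of the 2 values shown sits, shows, and compound 1 sits at the other limit, (the limit of > 1000 umol/kg in this assay, at which 1 of the 2 values shown sits). The step that the two limits leave unreadable from compound 1 to compound 2 is therefore unreadable in size. Compound 3 `COc1ccc(N/N=C2\CCC(C)n3c2ncc(C(=O)O)c3=O)cc1` differs from compound 2 by methyl in place of hydrogen on an oxygen on an aromatic ring. Among the measured compounds shown here, no measured step bears on this change, so no step beyond the scatter is expected; compound 3 is estimated at 300 umol/kg, within 100 umol/kg to 2000 umol/kg, meaning an expected step that the limit leaves unreadable from compound 2 to compound 3.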

Compound 3, dose for 50% inhibition: 7.6 umol/kg
Estimate against measurement, compound 3: 39-fold (1.60 log units) above; the whole stated range lies above it.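

On the 4-hydroxyphenyl group, methyl on the oxygen turns a compound held at a limit into one with a readable dose in this assay, with an at least 13-fold lower number from compound 2 to compound 3 (1.11 log units; beyond the scatter). Replacing 2-iodophenyl with 4-methoxyphenyl gives an at least 130-fold lower number from compound 1 to compound 3 (2.11 log units; beyond the scatter), and as both steps start from a limit of the assay, their true size may be larger. Nothing measured here gives a cause for this change. Still open, going by these compounds, is whether an ethoxy group in place of the methoxy group keeps this low dose, and whether an amine there does the same.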